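Alkyl substitution at the linker in a bombesin receptor agonist series

The compounds below may be only part of what the source reports. "The series", "measured", "known", "first", "only" and "open" are said of these compounds alone.

Measured so far:
compound 1, `CCCCc1cnc(C(C)Cc2ccc(-c3ccccc3C(=O)O)cc2)[nH]1`, 184 nM
compound 2, `CCCCc1cnc(C(CCC)Cc2ccc(-c3ccccc3C(=O)O)cc2)[nH]1`, 165 nM
compound 3, `CCCCc1cnc(CCc2ccc(-c3ccccc3C(=O)O)cc2)[nH]1`, 93 nM

In an in vitro functional assay on cells for agonist activity at Bombesin receptor subtype-3 (Mus musculus), read by luminescence and calcium flux (a lower number here means that less compound is needed, a higher number that more compound is needed for the effect), compound 1 gives 184 nM. Compound 2 carries ethyl in place of hydrogen on a saturated chain carbon, two bonds along the chain from an aromatic carbon and gives 165 nM, so the step of a 1.1-fold lower number from compound 1 to compound 2 (0.05 log units; within the scatter). Compound 3 differs from compound 1 by hydrogen in place of methyl on a saturated chain carbon bound to an aromatic carbon and a saturated chain carbon. In this assay compound 3 gives 93 nM. The steps of a 2.0-fold lower number from compound 1 to compound 3 (0.30 log units; within the scatter) and a 1.8-fold lower number from compound 2 to compound 3 (0.25 log units; within the scatter), so none of the three values can be told apart.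

Compound 4, `CCCCc1cnc(C(CC)Cc2ccc(-c3ccccc3C(=O)O)cc2)[nH]1`, is not yet measured. It differs from compound 3 by ethyl in place of hydrogen on a saturated chain carbon bound to an aromatic carbon and a saturated chain carbon. Among the measured compounds shown here, this is the same kind of change as the one from compound 1 to compound 2, though not the same: there the ethyl entered on a saturated chain carbon, two bonds along the chain from an aromatic carbon, whereas here it enters on a saturated chain carbon bound to an aromatic carbon and a saturated chain carbon. The earlier step was a 1.1-fold lower number from compound 1 to compound 2 (0.05 log units; within the scatter). Compound 1, with a substituent at this carbon, gave 184 nM, and compound 2, also with a substituent at this carbon, gave 165 nM. Taking this together, the step from compound 3 to compound 4 is expected to be a 1.6-fold higher number from compound 3 to compound 4 (0.21 log units; within the scatter), a small change within the scatter. Compound 4 is therefore estimated at 150 nM in this assay, with a likely range from 60 nM to 350 nM.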

Compound 4, half-maximal effective concentration: 340 nM
Estimate against measurement, compound 4: 2.3-fold (0.36 log units) below, and the stated range covers the measured number.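

Ethyl in place of hydrogen does not carry over as a fixed increment from one core to another in this assay: the same change on two cores in this assay, a 1.1-fold lower number (0.05 log units; within the scatter) from compound 1 to compound 2 and a 3.7-fold higher number (0.56 log units; beyond the scatter) from compound 3 to compound 4, 4.1-fold (0.61 log units) apart, beyond the scatter of two such steps. Hydrogen in place of methyl does not carry over as a fixed increment either: the same change on two cores in this assay, a 2.0-fold lower number (0.30 log units; within the scatter) from compound 1 to compound 3 and a 2.1-fold higher number (0.31 log units; beyond the scatter) from compound 2 to compound 4, 4.1-fold (0.61 log units) apart, beyond the scatter of two such steps. Among the compounds with a substituent at the saturated chain carbon bound to an aromatic carbon and a saturated chain carbon, a 2.1-fold higher number from compound 2 to compound 4 (0.31 log units; beyond the scatter) sets compound 4 apart from the propyl compound, whereas a 1.8-fold higher number from compound 1 to compound 4 (0.27 log units; within the scatter) does not set it apart from the methyl compound, and a 3.7-fold higher number from compound 3 to compound 4 (0.56 log units; beyond the scatter) sets it apart from the unsubstituted compound; these four compounds show that the steps at this carbon depend on the core they are made on, but they give neither a general rule for the series nor the reason for the difference.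

The methyl, ethyl and propyl compounds do not settle whether any steady relation to chain length exists at this carbon. Also open, going by these compounds, is how the series responds to a branched chain, a cyclopropyl group, a hydroxyl or an amine there, and whether the same lack of transfer holds for those groups.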